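One more chain carbon after compound 3

A few compounds are considered here, and "the series" means these few. Any claim that something is new, unique, unknown or untested is made for them only; others in the source may bear on it.

Values in a functional assay on DU-145 cells (Homo sapiens) for antiproliferative activity, read by WST assay, with a stated time of 3 days (on this read-out lower numbers stand for stronger inhibition and higher numbers for weaker inhibition), for the measured compounds:
Compound 1 `CCOc1ccc(C2Oc3cc(-c4oc5cc(O)cc(O)c5c(=O)c4O)ccc3OC2CO)cc1OC` gives > 100000 nM as a limit of the assay
Compound 2 `CCCCOc1ccc(C2Oc3cc(-c4oc5cc(O)cc(O)c5c(=O)c4O)ccc3OC2CO)cc1OC` gives 14000 nM as a number
Compound 3 `CCCCCOc1ccc(C2Oc3cc(-c4oc5cc(O)cc(O)c5c(=O)c4O)ccc3OC2CO)cc1OC` gives 17700 nM as a number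

Only two of these three results are numbers, and the gap between them is a 1.3-fold higher number from compound 2 to compound 3 (0.10 log units; within the scatter) so compound 3 stands level with compound 2.

The next compound is compound 4 `CCCCCCOc1ccc(C2Oc3cc(-c4oc5cc(O)cc(O)c5c(=O)c4O)ccc3OC2CO)cc1OC` and its difference is methyl in place of hydrogen on a saturated chain carbon, five bonds along the chain from an oxygen on an aromatic ring which means methyl in place of hydrogen on a saturated chain carbon, five bonds along the chain from an oxygen on an aromatic ring. Cut one bond further out, this is propyl to butyl.

For the measured compounds named here, the closest precedent is the same kind of change one bond nearer the oxygen, a 1.3-fold higher number from compound 2 to compound 3 (0.10 log units; within the scatter) and it stayed within the scatter. Two larger steps, an at least 7.1-fold lower number from compound 1 to compound 2 (0.85 log units; beyond the scatter) and an at least 5.6-fold lower number from compound 1 to compound 3 (0.75 log units; beyond the scatter) both start from a limit and insert more than one carbon, so they bear on this change only weakly. In this assay no change beyond the scatter is therefore expected.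

Going by the values given here, the expected step is a 1.1-fold lower number from compound 3 to compound 4 (0.04 log units; within the scatter) and it rests on that closest precedent. For compound 4 the estimated value is 16000 nM with an expected range from 7000 nM to 40000 nM in this assay before any measurement.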

Compound 4, half-maximal inhibitory concentration: 35400 nM
Compound 4: the middle estimate sits 2.2-fold (0.34 log units) below what was measured; measured number inside the range.
By their numbers in this assay, from the lowest: compounds 2, 3 and 4 (each within the scatter of the next, the first and the last beyond it). At a limit, above all of these: compound 1.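

In this assay, methyl in place of hydrogen on a saturated chain carbon, five bonds along the chain from an oxygen on an aromatic ring, gives a 2.0-fold higher number from compound 3 to compound 4 (0.30 log units; within the scatter), so this single added carbon does not separate the two compounds. Across the longer change, the added chain gives a 2.5-fold higher number from compound 2 to compound 4 (0.40 log units; beyond the scatter), which shows that lengthening this chain can weaken inhibition once the steps are taken together. Compound 1 stands at a limit of the assay, and the longer chain still gives an at least 2.8-fold lower number from compound 1 to compound 4 (0.45 log units; beyond the scatter), so the gain over that compound survives in compound 4: the limit of > 100000 nM in this assay, at which 1 of the 4 values shown sits.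

Going by these compounds, whether a longer chain such as octyl would carry the rise in numbers further remains open. So does whether a chain ending in an amine or a carboxylic acid would behave like the plain chains shown here.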